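Cyano on the Sulfonyl Phenyl Ring of Compound 2

The source may report more compounds than this note shows. Statements on the series, on what has been measured and on what is new or still open speak of the compounds shown alone.

compound 1 `O=S(=O)(c1ccccc1)N1CCOc2c(N3CCNCC3)cccc21`: 12.6 nM
compound 2 `Cc1cc(N2CCNCC2)c2c(c1)N(S(=O)(=O)c1ccccc1)CCO2`: 2.51 nM

In an assay on HEK293 cells for displacement of a labelled ligand from 5-hydroxytryptamine receptor 6 (Homo sapiens) (a lower number here means a stronger inhibitor, a higher number a weaker inhibitor), compound 2 gives the lowest of the two numbers, and compound 1 gives 12.6 nM; the step is a 5.0-fold lower number from compound 1 to compound 2 (0.70 log units; beyond the scatter). Compound 3 `Cc1cc(N2CCNCC2)c2c(c1)N(S(=O)(=O)c1ccccc1C#N)CCO2` differs from compound 2 by cyano in place of hydrogen on an aromatic carbon. For the measured compounds named here, the single measured step alters the shared core, not the sulfonyl phenyl ring, so no measured step bears on this change, and no move beyond the scatter is expected. The estimate for compound 3 in this assay is 3.2 nM, between 0.8 nM and 13 nM. For compound 3 this expectation amounts to a 1.3-fold higher number from compound 2 to compound 3 (0.11 log units; within the scatter), within the scatter.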

Compound 3, inhibition constant: 2 nM
The estimate for compound 3 lay 1.6-fold (0.20 log units) above the measured number, and the stated range covers the measured number.
By their numbers in this assay, from the lowest: compounds 3 and 2 (each within the scatter of the next); then compound 1.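

In this assay, for the compounds shown here, the change from phenyl to 2-cyanophenyl gives a 1.3-fold lower number from compound 2 to compound 3 (0.10 log units; within the scatter), the first measured step on the sulfonyl phenyl ring. It shows that a cyano group ortho to a large group can enter this ring without a move beyond the scatter, whereas the earlier step concerned only the shared core. No available evidence accounts for this result. On these data alone, it remains open whether an amine, a carboxylic acid or a methoxy group at this place would also leave the number within the scatter of compound 2.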